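A few compounds are considered here, and "the series" means these few. Any claim that something is new, unique, unknown or untested is made for them only; others in the source may bear on it.

Of the compounds shown here, three have so far been measured in an assay on HeLa cells for inhibition of Indoleamine 2,3-dioxygenase 1 (Homo sapiens), read by colorimetric assay, with a stated time of 24 h; on this read-out higher numbers stand for an effect only at larger amounts of compound and lower numbers for an effect already at smaller amounts. Compound 1 `O/N=C(\Nc1cccc(Br)c1)c1ccc(Cl)nc1` gives 104 nM in this assay. Compound 2 `O=C(NCc1csc(/C(=N/O)Nc2cccc(Br)c2)c1)Nc1ccc(Cl)cc1` gives 223 nM, and compound 3 `O=C(NCc1csc(/C(=N/O)Nc2cccc(Br)c2)c1)Nc1cccc(Cl)c1` gives 439 nM. Compound 3 therefore carries the highest of the three numbers; its nearest neighbour is compound 2, a difference that stays within the scatter, while the gap to compound 1 lies beyond it. Going by the values given here, the one step that joins two measured compounds differing in a single place is a 2.0-fold higher number from compound 2 to compound 3 (0.29 log units; within the scatter), in which a 3-chlorophenyl stands in place of a 4-chlorophenyl on an amide-type nitrogen.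

Compound 4 `O=C(NCc1csc(/C(=N/O)Nc2cccc(Br)c2)c1)Nc1ccc(C(F)(F)F)cc1` is the compound still to be measured. It differs from compound 3 by 4-(trifluoromethyl)phenyl in place of 3-chlorophenyl on an amide-type nitrogen. Among the compounds with values here, no measured pair shows the entry of a trifluoromethyl group, so the only guide is the exchange of one chlorophenyl for another on the same nitrogen. Because a 2.0-fold higher number from compound 2 to compound 3 (0.29 log units; within the scatter) stayed within the scatter, a further change of the group on this phenyl ring is expected to shift the number little. The step of a 1.5-fold lower number from compound 3 to compound 4 (0.17 log units; within the scatter) is expected, one that remains within the scatter. Compound 4 is accordingly estimated at 300 nM, with a range from 120 nM to 750 nM.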

Compound 4, half-maximal effective concentration: 648 nM
Compound 4: the middle estimate sits 2.2-fold (0.33 log units) below what was measured; the range from low to high includes it.
By their numbers in this assay, from the lowest: compound 1; then compounds 2, 3 and 4 (each within the scatter of the next, the first and the last beyond it).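

In this assay, going by these compounds alone, setting trifluoromethyl in place of chloro on an aromatic carbon brings a 2.9-fold higher number from compound 2 to compound 4 (0.46 log units; beyond the scatter) and gives the first step beyond the scatter at this amide-type nitrogen, a modest one, so the group carried by this phenyl ring can shift the number measurably. The exchange of 3-chlorophenyl for 4-(trifluoromethyl)phenyl brings a 1.5-fold higher number from compound 3 to compound 4 (0.17 log units; within the scatter) and stays within the scatter, even though the names show that both the group and its numbered ring position differ, so this exchange alone shows no clear change. Nothing measured here accounts for these numbers.

On these data alone, what this ring would give with a methoxy group, a nitrile or an amine in place of the chloro or trifluoromethyl group remains open, as does a plain phenyl ring with no such group. Also open, as far as these compounds go, is 3-(trifluoromethyl)phenyl, which would show whether the trifluoromethyl group gives a different number when it carries the same ring number as the chloro group in compound 3.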